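Anilide in place of benzyl amide on a chromone acrylamide

This account rests on a few compounds, and the source may have more. Where it says the series, first, only, none or still open, it means among the compounds named here.

Compound 1 `COc1ccc2c(=O)c(/C=C/C(=O)NCc3cccc(F)c3)coc2c1` was tested in a functional assay on A549 cells (Homo sapiens) for inhibition, read by MTT assay, with a stated time of 48 h (on this read-out higher numbers stand for weaker inhibition and lower numbers for stronger inhibition), and compound 1 gave 26900 nM. Within the data shown here, compound 2 `O=C(/C=C/c1coc2cc(O)ccc2c1=O)Nc1ccccc1` is the only other measured compound; in this assay compound 2 gave 24400 nM, and the two values lie within the scatter of each other, so neither compound can be set apart. Compound 3 `CCOc1ccc(NC(=O)/C=C/c2coc3cc(OC)ccc3c2=O)cc1` differs from compound 1 by 4-ethoxyphenyl in place of 3-fluorobenzyl on an amide-type nitrogen. Among the measured compounds shown here, no measured pair separates these two groups, and since compound 2 with its anilide gives 24400 nM, which sits near the number for compound 1, the step of a 1.2-fold lower number from compound 1 to compound 3 (0.07 log units; within the scatter) is expected to stay within the scatter. Compound 3 is therefore estimated at 23000 nM, with a range from 8000 nM to 65000 nM.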

Compound 3, half-maximal inhibitory concentration: > 100000 nM
Compound 3 was reported as a limit; the forecaster's own chance of this, stated with the estimate: 10%; middle value at least 4.3-fold (0.63 log units) away from the limit.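

In this assay, 4-ethoxyphenyl in place of 3-fluorobenzyl on the amide-type nitrogen gives an at least 3.7-fold higher number from compound 1 to compound 3 (0.57 log units; beyond the scatter), so activity at this position depends on the group it carries. Compound 3 is reported as a limit: the limit of > 100000 nM in this assay, at which 1 of the 3 values shown sits.

This change swaps the benzyl link for a direct aryl link and also replaces the fluorine with an ethoxy group, and the compounds shown cannot separate these two differences. Neither 4-ethoxybenzyl nor 3-fluorophenyl on the same nitrogen is among them, and either one would pull the two apart.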